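Trading the triazole for an ester on the thioether arm

The compounds below may be only part of what the source reports. "The series", "measured", "known", "first", "only" and "open" are said of these compounds alone.

Of the compounds shown here, three sharing one core have been tested in an assay on CHO cells for displacement of a labelled ligand from adenosine receptor A3 (Homo sapiens), read by scintillation counting, with a stated time of 120 min, tested at 1 uM; a higher number here means more inhibition at the concentration tested (going by the name of the read-out), a lower number less inhibition. Compound 1, `N#Cc1c(N)nc(SCc2cccnc2)c(C#N)c1-c1ccc(OCC2CC2)cc1`, gives 19%. Compound 2, `N#Cc1c(N)nc(SCc2ccn[nH]2)c(C#N)c1-c1ccc(OCC2CC2)cc1`, gives 6% in this assay, and compound 3, `N#Cc1c(N)nc(SCn2cncn2)c(C#N)c1-c1ccc(OCC2CC2)cc1`, gives 1%. Compound 3 therefore holds the lowest of the three numbers: its nearest neighbour is compound 2, within the scatter, while the gap to compound 1 is beyond it. The measured steps were all changes of the group on a saturated chain carbon bound to a sulfur: a number 13 percentage points lower from compound 1 to compound 2 (beyond the scatter), a number 18 percentage points lower from compound 1 to compound 3 (beyond the scatter), and a number 5 percentage points lower from compound 2 to compound 3 (within the scatter).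

Compound 4, `COC(=O)CSc1nc(N)c(C#N)c(-c2ccc(OCC3CC3)cc2)c1C#N`, alters that same position: methoxycarbonyl in place of 1H-1,2,4-triazol-1-yl on a saturated chain carbon bound to a sulfur. Going by the values given here, no measured step replaces a ring there with an open-chain group, so the bearing of the earlier steps is indirect; they only show that swaps at this position moved the number by modest amounts, and that compound 3 already sits near the bottom of the scale. A step of any size in either direction beyond the scatter is not expected, though a slight rise cannot be ruled out. Compound 4 is thus estimated at 6%, in a range from -5% to 22%, which means an expected step of a number 5 percentage points higher from compound 3 to compound 4 (within the scatter).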

Compound 4, a percentage reported as inhibition, at one concentration (the size of the read-out at that concentration, not a potency): 1%
The estimate for compound 4 lay 5 percentage points above the measured number; the measured number falls inside the stated range.
By their numbers in this assay, from the lowest: compounds 3, 4 and 2 (each within the scatter of the next); then compound 1.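

Going by these compounds alone, compound 4 is the first in the set to carry an open-chain group on the saturated chain carbon bound to a sulfur, and in this assay methoxycarbonyl cannot be told apart from the five-membered aromatic rings: the result is no change at the digits printed from compound 3 to compound 4 (within the scatter) and a number 5 percentage points lower from compound 2 to compound 4 (within the scatter). Within the data shown here, a ring at this position is therefore not needed for a number this close to the bottom of the scale, and pyridin-3-yl remains the only group here that stands apart, with a number 18 percentage points lower from compound 1 to compound 4 (beyond the scatter), the same gap as the one printed for the triazole. Nothing given here accounts for why methoxycarbonyl and the two five-membered rings read alike.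

The compounds shown leave open whether any other open-chain group, such as a carboxylic acid, a primary amide or a longer chain ending in an amine, would lift the number beyond the scatter. They also leave open whether a six-membered ring such as pyridin-4-yl or phenyl would match or exceed compound 1, and all of these readings come from a single concentration, so they say nothing of potency.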